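The source may report more compounds than this note shows. Statements on the series, on what has been measured and on what is new or still open speak of the compounds shown alone.

Three compounds share one core and differ only in the aromatic group attached to a ring nitrogen. Compound 1 `COc1cc(/C=C/C(C)=O)ccc1OCc1cn(-c2c(F)cccc2F)nn1` gives 37700 nM in a functional assay on HCT-116 cells (Homo sapiens) for antiproliferative activity, read by MTT assay, with a stated time of 48 h; on this read-out higher numbers stand for weaker inhibition and lower numbers for stronger inhibition. Compound 2 `COc1cccc(-n2cc(COc3ccc(/C=C/C(C)=O)cc3OC)nn2)c1` gives 29600 nM in this assay, and the step of a 1.3-fold lower number from compound 1 to compound 2 (0.11 log units; within the scatter) is too small to count as a change. Compound 3 `COc1cc(/C=C/C(C)=O)ccc1OCc1cn(-c2ccc([N+](=O)[O-])cc2)nn1` gives 96300 nM in this assay, the highest of the three numbers: the steps of a 2.6-fold higher number from compound 1 to compound 3 (0.41 log units; beyond the scatter) and a 3.3-fold higher number from compound 2 to compound 3 (0.51 log units; beyond the scatter) both run upward, so compound 3 is the weakest inhibitor of the three on this read-out.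

Compound 4 `COc1cc(/C=C/C(C)=O)ccc1OCc1cn(-c2ccc(C=O)cc2)nn1` is the next compound to be measured. It keeps the core and ring of compound 3, with formyl in place of nitro on an aromatic carbon. None of the three measured steps tests this particular swap; the two steps that involve compound 3 change the whole aromatic group, not one substituent on it, and both were only modest in size. Among the measured compounds shown here, with no measured step to lean on, a small step is expected for compound 4, possibly one that stays within the scatter of repeated measurements: the expected step is a 1.6-fold lower number from compound 3 to compound 4 (0.21 log units; within the scatter). Compound 4 is therefore estimated at 60000 nM in this assay, with a range from 20000 nM to 180000 nM.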

Compound 4, half-maximal inhibitory concentration: 76200 nM
Compound 4: the middle estimate sits 1.3-fold (0.10 log units) below what was measured; the range from low to high includes it.
By their numbers in this assay, from the lowest: compounds 2 and 1 (each within the scatter of the next); then compounds 4 and 3 (each within the scatter of the next).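

Replacing nitro with formyl on the aromatic carbon para to a large group gives a 1.3-fold lower number from compound 3 to compound 4 (0.10 log units; within the scatter) in this assay, so the two groups cannot be told apart at this position, and this is the first step among these compounds that changes one substituent rather than the whole aromatic group. The 4-formylphenyl group also keeps the number up against the other two aromatic groups, with a 2.6-fold higher number from compound 2 to compound 4 (0.41 log units; beyond the scatter) and a 2.0-fold higher number from compound 1 to compound 4 (0.31 log units; beyond the scatter), both modest steps that resemble those already seen for 4-nitrophenyl. Among these four compounds, compound 3 and compound 4 therefore sit together at the weaker end, with compound 1 and compound 2 at the stronger end, and no accompanying measurement explains this gap.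

Going by these compounds, it remains open whether any group at this position can bring the number down, since nitro and formyl alone say little about what an amine, a hydroxyl or a carboxylic acid would do in the same place. On these data alone, it is equally open whether formyl would give a similar number at another place on the ring.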